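The compounds below may be only part of what the source reports. "The series", "measured", "known", "first", "only" and "open" are said of these compounds alone.

Working notes on the series. In a functional assay on MT4 cells (Homo sapiens) for antiproliferative activity, read by MTT assay, with a stated time of 96 h (on this read-out higher numbers stand for an effect only at larger amounts of compound and lower numbers for an effect already at smaller amounts), compound 3 `COCCOC(=O)/C(C#N)=C/c1c(-c2ccccc2)[nH]c2ccccc12` gives 1200 nM, the highest of the three numbers; compound 1 `COC(=O)/C(=C\c1c(-c2ccccc2)[nH]c2ccccc12)S(=O)(=O)c1ccccc1` gives 1000 nM, within the scatter of compound 3, while compound 2 `CC(=O)/C(=C\c1c(-c2ccccc2)[nH]c2ccccc12)S(=O)(=O)c1ccccc1` gives 400 nM, beyond the scatter of compound 3. Compound 4 `N#C/C(=C\c1c(-c2ccccc2)[nH]c2ccccc12)S(=O)(=O)c1ccccc1` differs from compound 3 by phenylsulfonyl in place of (2-methoxyethoxy)carbonyl on a double-bonded chain carbon bound to a double-bonded chain carbon and a triple-bonded carbon. For the measured compounds named here, no measured step covers this exchange; the single step, a 2.5-fold lower number from compound 1 to compound 2 (0.40 log units; beyond the scatter), concerns methyl in place of methoxy on a carbonyl carbon and so bears only loosely. Compounds 1 and 2 both carry phenylsulfonyl and fall level with or below compound 3 in this assay. Compound 4 is therefore expected to sit near them, the estimated step being a 2.0-fold lower number from compound 3 to compound 4 (0.30 log units; within the scatter). The estimate for compound 4 is 600 nM, with a range of 200 nM to 2000 nM.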

Compound 4, half-maximal effective concentration: 400 nM
The estimate for compound 4 lay 1.5-fold (0.18 log units) above the measured number; the measured number falls inside the stated range.
By their numbers in this assay, from the lowest: compounds 2 and 4 (each within the scatter of the next); then compounds 1 and 3 (each within the scatter of the next).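

Phenylsulfonyl in place of (2-methoxyethoxy)carbonyl gives a 3.0-fold lower number from compound 3 to compound 4 (0.48 log units; beyond the scatter) in this assay as the first direct reading of this exchange on a carbon that keeps its nitrile. With phenylsulfonyl kept, cyano in place of acetyl gives no change at the digits printed from compound 2 to compound 4 (within the scatter) while cyano in place of methoxycarbonyl gives a 2.5-fold lower number from compound 1 to compound 4 (0.40 log units; beyond the scatter) and so cyano and acetyl read alike at this position. Nothing at hand gives a reason for these steps. Open remains how a carboxylic acid or an amide at this position would read with phenylsulfonyl kept. Also open, as far as these compounds go, is how a phenylsulfonyl bearing a methoxy group would read with the nitrile kept.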